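This account rests on a few compounds, and the source may have more. Where it says the series, first, only, none or still open, it means among the compounds named here.

Working notes on the series

Compound 1 `CC(NC(=O)c1ncc([N+](=O)[O-])n1C)c1ccc(F)cc1` carries the shared core with a methyl on the aromatic nitrogen. In a toxicity assay on HepG2 cells (Homo sapiens) for inhibition, read by resazurin assay, with a stated time of 24 h (a higher number here means that more compound is tolerated, a lower number that less compound is tolerated), compound 1 reaches only the assay limit, > 100000 nM. Compound 3 `CC(NC(=O)c1ncc([N+](=O)[O-])[nH]1)c1ccc(F)cc1` differs from compound 1 by hydrogen in place of methyl on an aromatic nitrogen. In this assay compound 3 likewise stops at a limit, > 100000 nM. The step that the two limits leave unreadable from compound 1 to compound 3 cannot be read, which rests on (the limit of > 100000 nM in this assay, at which 3 of the 3 values shown sit).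

Compound 2 `Cn1c([N+](=O)[O-])cnc1C(=O)NC1CCCCC1` has a different core; the difference between the two cores is not broken down here. In this assay compound 2 also gives a limit, > 100000 nM.

Compound 4 `O=C(NC1CCCCC1)c1ncc([N+](=O)[O-])[nH]1` remains unmeasured and differs from compound 2 by hydrogen in place of methyl on an aromatic nitrogen. This is the same kind of change as that between compound 1 and compound 3, though its place is given as next to the ring atom that bears a group of 9 heavy atoms, where the earlier one reads a large group. In this assay the step of a number no higher from compound 2 to compound 4 (the limit leaves the size open) is expected, resting on the shared limit in the limit of > 100000 nM in this assay, at which 3 of the 3 values shown sit. Compound 4 is therefore estimated at 100000 nM, with a range from 50000 nM to 300000 nM, most likely returned as a limit again.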

Compound 4, half-maximal cytotoxic concentration: > 100000 nM
Compound 4 ended at the assay's limit; the forecaster's own chance of this, stated with the estimate: 85%; the middle value sits exactly at the limit.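

In this assay compound 2 and compound 4 both stop at a limit, so no step can be read between them: the limit of > 100000 nM in this assay, at which 4 of the 4 values shown sit.

The compounds shown leave open what size, if any, the change to hydrogen in place of methyl on an aromatic nitrogen has in this assay, and where any of the four compounds would give a readable number.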